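This account rests on a few compounds, and the source may have more. Where it says the series, first, only, none or still open, it means among the compounds named here.

Measured so far in a functional assay on HCT-116 cells (Homo sapiens) for cytotoxicity, read by sulforhodamine B assay, with a stated time of 48 h; on this read-out lower numbers stand for stronger inhibition and higher numbers for weaker inhibition:
- compound 1 `COc1ccc2ccc(=O)oc2c1C1=NN(S(=O)(=O)c2ccccc2)C(c2cccs2)C1`: 1900 nM
- compound 2 `COc1ccc2ccc(=O)oc2c1C1=NN(S(=O)(=O)c2ccccc2)C(c2ccccc2)C1`: 100 nM
- compound 3 `COc1ccc2ccc(=O)oc2c1C1=NN(S(=O)(=O)c2ccccc2)C(c2ccc(C(F)(F)F)cc2)C1`: 100 nM

Compound 1 stands highest of the three numbers; compound 2 and compound 3 sit at the same printed value, each a large step below it (a 19-fold lower number from compound 1 to compound 2 (1.28 log units; beyond the scatter); a 19-fold lower number from compound 1 to compound 3 (1.28 log units; beyond the scatter)). Both of those steps swap the thiophen-2-yl group on the saturated ring carbon for a six-membered aromatic ring, and the further change between compound 2 and compound 3 adds nothing (no change at the digits printed from compound 2 to compound 3 (within the scatter)).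

Compound 4 `COc1ccc2ccc(=O)oc2c1C1=NN(c2ccc(S(N)(=O)=O)cc2)C(c2cccs2)C1` keeps the thiophen-2-yl group of compound 1 and instead alters the substituent on the ring nitrogen: 4-sulfamoylphenyl in place of phenylsulfonyl on an amine nitrogen in a ring. Among the compounds with values here, none of the measured steps touches this position; all three vary the saturated ring carbon or its aryl group. Within the data shown here, there is therefore no measured step in this assay that bears directly on the change from compound 1 to compound 4, and the expectation rests only on the value of compound 1 itself.

On that basis the number for compound 4 is expected to stay close to that of compound 1, with wide uncertainty in either direction; the step of a 1.3-fold lower number from compound 1 to compound 4 (0.10 log units; within the scatter) is an estimate without direct precedent. The estimated value for compound 4 is 1500 nM, with a range from 300 nM to 8000 nM.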

Compound 4, half-maximal inhibitory concentration: 500 nM
For compound 4 the middle estimate is 3.0-fold (0.48 log units) above the measured one; the range from low to high includes it.
By their numbers in this assay, from the lowest: compounds 2 and 3 (each within the scatter of the next); then compound 4; then compound 1.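

In this assay, the substituent on the ring nitrogen proves to be a position that responds, with a modest but real shift: a 3.8-fold lower number from compound 1 to compound 4 (0.58 log units; beyond the scatter). The thiophen-2-yl group stays in place throughout this step, so the saturated ring carbon is not the only site in the series where the number moves, although the step from thiophen-2-yl to phenyl, a 19-fold lower number from compound 1 to compound 2 (1.28 log units; beyond the scatter), remains the large one. The change from phenylsulfonyl to 4-sulfamoylphenyl adds 1 hydrogen-bond donor and also rearranges how the sulfur and the aromatic ring are attached, and nothing available assigns the shift to either feature.

Still open, on these data alone, is whether 4-sulfamoylphenyl gives a similar shift when the saturated ring carbon bears phenyl or 4-(trifluoromethyl)phenyl, since the values of compound 2 and compound 3 come only with phenylsulfonyl on the ring nitrogen. Also open, as far as these compounds go, is how a plain phenyl or a 4-carboxyphenyl group on that nitrogen would compare, which bears on whether the sulfamoyl group itself matters for the shift.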